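This account rests on a few compounds, and the source may have more. Where it says the series, first, only, none or still open, it means among the compounds named here.

Going by the values given here, compound 1 `O=c1[nH]nc2n(c1=O)CCN2c1ccccc1` is the first of two close relatives that have been tested. In a functional assay on T47D cells (Homo sapiens) for cytotoxicity, with a stated time of 72 h, tested at 50 ug/mL (on this read-out higher numbers stand for a stronger effect at the one concentration tested and lower numbers for a weaker effect), compound 1 gives 0%. Compound 2 `Cc1ccccc1N1CCn2c1n[nH]c(=O)c2=O` differs from it only by a methyl in place of hydrogen on an aromatic carbon, and in this assay compound 2 gives 0%. The step of no change at the digits printed from compound 1 to compound 2 (within the scatter) shows that this small addition left the read-out where it was, and compound 2 therefore stands level with compound 1 on the numbers shown, with no effect recorded for either at the single concentration tested.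

Compound 3 `COc1ccccc1N1CCn2c1n[nH]c(=O)c2=O` has not yet been measured. It differs from compound 2 by methoxy in place of methyl on an aromatic carbon.

Among the compounds with values here, only one measured step exists, the one from compound 1 to compound 2, and it concerns a different replacement on the same aromatic carbon; it is the nearest guide, and its size was nil. Within the data shown here, no step covers methoxy in place of methyl directly. With both measured compounds showing no effect, compound 3 is expected to show no change at the digits printed from compound 2 to compound 3 (within the scatter), nothing beyond the scatter. The estimate for compound 3 in this assay is therefore 0%, expected to fall between 0% and 10%.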

Compound 3, a percentage reported as inhibition, at one concentration (the size of the read-out at that concentration, not a potency): 9%
Compound 3: the middle estimate sits 9 percentage points below what was measured, within the range that was stated.
By their numbers in this assay, from the lowest: compounds 1, 2 and 3 (each within the scatter of the next).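

In this assay, replacing methyl with methoxy on this aromatic carbon, ortho to a large group, adds one oxygen and one hydrogen-bond acceptor and gives a number 9 percentage points higher from compound 2 to compound 3 (within the scatter). Set against the compound that carries only hydrogen at the same place, methoxy gives a number 9 percentage points higher from compound 1 to compound 3 (within the scatter), so both comparisons are printed as within the scatter, and hydrogen, methyl and methoxy at this position cannot be told apart on this read-out. No supporting measurement is available to connect these numbers to any property of the methoxy group.

On these data alone, it remains open whether a different kind of group at this position, such as an amine, a carboxylic acid, chlorine or a longer chain such as butoxy, would move the read-out beyond the scatter. It is also open what the same groups would do on other carbons of this ring, and a read-out at one concentration gives no measure of potency for any of these compounds.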